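This account rests on a few compounds, and the source may have more. Where it says the series, first, only, none or still open, it means among the compounds named here.

Measured compounds:
compound 1 `O=C1CS/C(=N/Nc2nncc3ccccc23)N1c1ccccc1` — 3 nM
compound 2 `NC(=S)NNc1nncc2ccccc12` — 94 nM
compound 3 `O=S(=O)(Nc1ncccn1)c1ccc(Nc2nncc3ccccc23)cc1` — 67 nM

In a functional assay on HL-60 cells (Homo sapiens) for antiproliferative activity, read by sulforhodamine B assay, with a stated time of 72 h (a higher number here means a weaker inhibitor, a lower number a stronger inhibitor), compound 1 gives 3 nM, the lowest of the three numbers. The nearest other number is that of compound 3, and compound 2 lies furthest away; both gaps are beyond the usual scatter, so compound 1 is the strongest inhibitor of the three in this assay. Compound 4 `CCN1C(=O)CS/C1=N/Nc1nncc2ccccc12` has not yet been measured. It differs from compound 1 in one place: ethyl in place of phenyl on an amide-type nitrogen in a ring. For the measured compounds named here, no pair of measured compounds shows this change, so the present numbers give no measured size for such a step. Because compound 1 gives 3 nM and the other two compounds sit well above it, a loss is judged more likely than a gain when the phenyl is exchanged for ethyl. The expected step from compound 1 to compound 4 is a 5.0-fold higher number from compound 1 to compound 4 (0.70 log units; beyond the scatter), a weakening of moderate size. Compound 4 is therefore estimated at 15 nM, with a range from 3 nM to 80 nM.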

Compound 4, half-maximal inhibitory concentration: 3 nM
The estimate for compound 4 lay 5.0-fold (0.70 log units) above the measured number, within the range that was stated.
By their numbers in this assay, from the lowest: compounds 1 and 4 (each within the scatter of the next); then compounds 3 and 2 (each within the scatter of the next).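

In this assay, for the compounds shown here, the exchange of phenyl for ethyl on the amide-type nitrogen in a ring gives no change at the digits printed from compound 1 to compound 4 (within the scatter) and so provides the first measured step at this position. In this pair, the six-membered aromatic ring of carbon only can be replaced by a group with no ring and fewer heavy atoms, with no change beyond the scatter. Nothing shown here offers evidence that would explain this outcome.

From the compounds shown here alone, whether the position accepts other groups remains open: a longer chain such as butyl, a benzyl group or a chain ending in an amine could hold the number at this level or lose it. This single pair also leaves open whether the same exchange would behave alike on a different core.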